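The source may report more compounds than this note shows. Statements on the series, on what has been measured and on what is new or still open speak of the compounds shown alone.

For the measured compounds named here, compound 2 `NC/C=C(/F)COc1ccc(OC(F)(F)F)cc1` gives 70 nM in an assay on isolated protein for inhibition of Amine oxidase [flavin-containing] B (Homo sapiens), read by Amplex Red (on this read-out lower numbers stand for stronger inhibition and higher numbers for weaker inhibition), and stands lowest of the two numbers measured so far; compound 1 `COc1ccc(OC/C(F)=C\CN)cc1` gives 310 nM in the same assay. Going by the values given here, the one step known, a 4.4-fold lower number from compound 1 to compound 2 (0.65 log units; beyond the scatter), is trifluoromethyl in place of methyl on an oxygen on an aromatic ring.

Compound 3 `NC/C=C(/F)COc1ccc(C(F)(F)F)cc1` is not yet measured. It differs from compound 2 by trifluoromethyl in place of trifluoromethoxy on an aromatic carbon, on an aromatic carbon of a six-membered aromatic ring of carbon only. Among the compounds with values here, no measured step removes the oxygen of an aromatic ether while keeping the trifluoromethyl; the step from compound 1 to compound 2 changed only the group on the oxygen and does not tell how the oxygen itself counts. With nothing to set a direction, compound 3 is expected to sit near compound 2, with a 1.4-fold higher number from compound 2 to compound 3 (0.15 log units; within the scatter) within the scatter. Compound 3 is therefore estimated at 100 nM, between 30 nM and 350 nM.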

Compound 3, half-maximal inhibitory concentration: 130 nM
Compound 3: the middle estimate sits 1.3-fold (0.11 log units) below what was measured; low and high end bracket the measured number.
By their numbers in this assay, from the lowest: compounds 2 and 3 (each within the scatter of the next); then compound 1.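

In this assay, taking the oxygen out of the trifluoromethoxy group while keeping the trifluoromethyl leaves the number within the scatter, with a 1.9-fold higher number from compound 2 to compound 3 (0.27 log units; within the scatter) as the step. Replacing methoxy directly with trifluoromethyl still counts, with a 2.4-fold lower number from compound 1 to compound 3 (0.38 log units; beyond the scatter) as the step, so the lower number seen with trifluoromethoxy does not need an oxygen on the aromatic carbon, and both fluorinated groups now stand apart from methoxy at this place. Nothing available explains why these groups read as they do.

As far as these compounds go, whether the fluorines of the trifluoromethyl are what matters stays open, since a plain methyl, a chlorine or a nitrile at this aromatic carbon would be needed to tell. The compounds shown also leave open how an amine or a carboxylic acid at this place would read.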